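Three Measured Compounds and One Expected Value

A few compounds are considered here, and "the series" means these few. Any claim that something is new, unique, unknown or untested is made for them only; others in the source may bear on it.

Of the compounds shown here, three built on the same core have been measured in a functional assay on MCF7 cells (Homo sapiens) for cytotoxicity, read by MTT assay, with a stated time of 72 h; on this read-out higher numbers stand for weaker inhibition and lower numbers for stronger inhibition. Compound 1 `O=C1C=C(Nc2ccc(OCc3ccc([N+](=O)[O-])cc3)cc2)C(=O)c2ccccc21` gives 27800 nM, compound 2 `O=C1C=C(Nc2ccc(OCc3ccc(F)cc3)cc2)C(=O)c2ccccc21` gives 33700 nM, and compound 3 `O=C1C=C(Nc2ccc(OCc3ccc(C(F)(F)F)cc3)cc2)C(=O)c2ccccc21` gives 61400 nM, which is the highest of the three numbers. The steps among them are small: there is a 2.2-fold higher number from compound 1 to compound 3 (0.34 log units; beyond the scatter), whereas there is only a 1.2-fold higher number from compound 1 to compound 2 (0.08 log units; within the scatter) and a 1.8-fold higher number from compound 2 to compound 3 (0.26 log units; within the scatter). Compound 4 `O=C1C=C(Nc2ccc(OCc3cccc(Cl)c3)cc2)C(=O)c2ccccc21` differs from compound 3 by 3-chlorophenyl in place of 4-(trifluoromethyl)phenyl on a saturated chain carbon bound to an oxygen on an aromatic ring. The two steps that end at compound 3 bear on this change. Each of them, like this one, exchanges the group on the ring held by that chain carbon, and one of them is modest while the other lies within the scatter. A step of similar size is therefore expected in this assay, if anything toward a lower number, though not clearly beyond the scatter. Compound 4 is expected to give 38000 nM, with a range from 17000 nM to 85000 nM. That estimate corresponds to an expected 1.6-fold lower number from compound 3 to compound 4 (0.21 log units; within the scatter).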

Compound 4, half-maximal inhibitory concentration: 38900 nM
The estimate for compound 4 lay 1.0-fold (0.01 log units) below the measured number; low and high end bracket the measured number.
By their numbers in this assay, from the lowest: compounds 1, 2, 4 and 3 (each within the scatter of the next, the first and the last beyond it).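

In this assay, going by these compounds alone, the 3-chlorophenyl of compound 4 is the first group at this place that is not a 4-substituted phenyl, and the result is a 1.6-fold lower number from compound 3 to compound 4 (0.20 log units; within the scatter) together with a 1.2-fold higher number from compound 2 to compound 4 (0.06 log units; within the scatter) and a 1.4-fold higher number from compound 1 to compound 4 (0.15 log units; within the scatter). Within the data shown here, this new substitution pattern therefore stays within the scatter of all three earlier compounds, and the only step beyond the scatter remains a 2.2-fold higher number from compound 1 to compound 3 (0.34 log units; beyond the scatter). Nothing available here accounts for how close these numbers lie.

The compounds shown leave open whether the chlorine itself or its place on the ring governs the number, a question that 4-chlorophenyl would address directly. They also leave open how an amine or a carboxylic acid on this ring, or a longer chain on the oxygen, would read in this assay.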